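Removing a Propyl Group from an Inactive Prostaglandin Analogue

A few compounds are considered here, and "the series" means these few. Any claim that something is new, unique, unknown or untested is made for them only; others in the source may bear on it.

Compound 1 `CCc1cccc(C[C@H](O)/C=C/[C@H]2COC(=O)N2CCSCCCC(=O)O)c1`: > 10000 nM
Compound 2 `CCCc1cccc(C[C@H](O)/C=C/[C@H]2CSC(=O)N2CCSCCCC(=O)O)c1`: > 10000 nM

Of the compounds shown here, two have so far been tested in an assay on CHO cells for displacement of a labelled ligand from prostaglandin E2 receptor EP2 subtype (Mus musculus), read by scintillation counting, with a stated time of 60 min; on this read-out lower numbers stand for stronger inhibition and higher numbers for weaker inhibition. Compound 1 gives > 10000 nM, which is a limit of the assay rather than a number. Compound 2 gives > 10000 nM, again a limit and not a measured number. Both values sit at the limit of > 10000 nM in this assay, at which 2 of the 2 values shown sit, so compound 2 stands at the edge of what the assay can report, showing no measurable binding, and the two compounds cannot be told apart on these numbers.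

Compound 3 `O=C(O)CCCSCCN1C(=O)SC[C@@H]1/C=C/[C@@H](O)Cc1ccccc1` has not yet been measured. It differs from compound 2 by hydrogen in place of propyl on an aromatic carbon. With compound 2 already at the limit and no measured step between related compounds to lean on, there is no basis for expecting a change beyond the scatter, and no reason to expect binding to appear. Compound 3 is therefore expected to give about 20000 nM, with a likely range from 5000 nM to 100000 nM. The step that the limit leaves unreadable from compound 2 to compound 3 is estimated to be none beyond the scatter, and the assay will most likely again report only a limit.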

Compound 3, inhibition constant: > 10000 nM
Compound 3 was reported as a limit (the forecaster's own chance of this, stated with the estimate: 85%); the middle value does not contradict the limit.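

In this assay compound 3 gives > 10000 nM, which is a limit of the assay and not a number. Compound 2 also stands at a limit, so no step can be read between compound 2 and compound 3. The compounds shown leave open whether the propyl group affects binding at all, and which change would bring a measurable number, as every value sits at the same edge: the limit of > 10000 nM in this assay, at which 3 of the 3 values shown sit.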